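The compounds below may be only part of what the source reports. "The series", "measured", "known", "first", "only" and "open" are said of these compounds alone.

Of the compounds shown here, three have so far been tested in a functional assay on the whole organism (strain Wistar Albino) for inhibition, with Rattus norvegicus as the target, read by paw edema, with a stated time of 2 h, at a dose of 20 mg/kg; a higher number here means more inhibition at the dose given (going by the name of the read-out), a lower number less inhibition. Compound 1 `COc1ccc2[nH]c(C)c(Cc3nn4c(Cc5ccc(OC)c(OC)c5)nnc4s3)c2c1` gives 16.2% in this assay. Compound 2 `Cc1occc1-c1nnc2n1NC(c1ccco1)S2` gives 21.6%, and compound 3 `Cc1occc1-c1nnc2n1NC(c1ccc([N+](=O)[O-])o1)S2` gives 18.1%. Among these three numbers compound 2 stands highest, but its nearest neighbour, compound 3, lies a number 3.5 percentage points lower from compound 2 to compound 3 (within the scatter) away, which is within the scatter, and compound 1 sits only a little further off, also within the scatter; the three values therefore cannot be told apart with confidence.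

Compound 4 `Cc1occc1-c1nnc2n1NC(c1cccn1C)S2` has not yet been measured. It differs from compound 2 in one place: 1-methyl-1H-pyrrol-2-yl in place of furan-2-yl on a saturated ring carbon. Among the measured compounds shown here, no measured step exchanges one five-membered aromatic ring for another, so none bears directly on this change. For the measured compounds named here, the only step available, adding a nitro group to the furan-2-yl ring of compound 2 to give compound 3, moved the read-out by a number 3.5 percentage points lower from compound 2 to compound 3 (within the scatter), a shift within the scatter. On that basis, and with the rest of the molecule unchanged, compound 4 is expected to give about 20% in this assay, most likely between 10% and 30%. This corresponds to an expected step of a number 1.6 percentage points lower from compound 2 to compound 4 (within the scatter), with no movement beyond the scatter anticipated.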

Compound 4, a percentage reported as inhibition, in the whole organism at one dose (the size of the read-out at that dose, not a potency): 18.9%
Compound 4: the middle estimate sits 1.1 percentage points above what was measured; the range from low to high includes it.
By their numbers in this assay, from the lowest: compounds 1, 3, 4 and 2 (each within the scatter of the next).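

Replacing furan-2-yl with 1-methyl-1H-pyrrol-2-yl on the saturated ring carbon exchanges the whole five-membered aromatic ring at this position, whereas the earlier step in this series only added a nitro group to the furan-2-yl ring. In this assay this exchange gives a number 2.7 percentage points lower from compound 2 to compound 4 (within the scatter) and so shows that this position, on the saturated ring carbon next to the ring nitrogen and next to the ring sulfur, can carry a methylated nitrogen ring in place of an oxygen ring with no difference that stands clear of the scatter. Nothing measured explains this outcome or shows which feature of either ring, if any, matters to the read-out.

From the compounds shown here alone, since the steps from compound 2 to compound 3 and to compound 4 both stay within the scatter, it remains open whether any group at this position can shift the read-out in a way that can be told from repeated measurement. Whether a non-aromatic group here, such as an amine like piperidine, a carboxylic acid or a longer alkyl chain, would do so stays unanswered by the compounds shown.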